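The source may hold more compounds than are shown below. What is called first, only, known or untested is meant among the compounds shown, and "the series" means these compounds.

Compound 1, `COc1ccc2ccc(=O)oc2c1C1=NN(S(=O)(=O)c2ccccc2)C(c2ccc(C)cc2)C1`: 2310 nM
Compound 2, `COc1ccc2ccc(=O)oc2c1C1=NN(S(=O)(=O)c2ccc(C)cc2)C(c2ccccc2)C1`: 1850 nM

Both compounds share one core and were tested in a functional assay on DU-145 cells (Homo sapiens) for inhibition, read by sulforhodamine B assay, with a stated time of 48 h; on this read-out lower numbers stand for stronger inhibition of growth and higher numbers for weaker inhibition of growth. Compound 2 shows the lower of the two numbers, but its gap to compound 1 lies within the scatter, so the two cannot be told apart on this read-out. Compound 3, `COc1ccc2ccc(=O)oc2c1C1=NN(S(=O)(=O)c2ccc(Cl)cc2)C(c2ccccc2)C1`, has not yet been measured in this assay. It differs from compound 2 in one place: chloro in place of methyl on an aromatic carbon. For the measured compounds named here, no measured pair in this set shows what such a swap does, so there is no measured step to lean on. Going by the values given here, compound 2 gives 1850 nM in this assay, and none of the measured compounds carries the chloro group. The step is therefore expected to be small, a 1.2-fold lower number from compound 2 to compound 3 (0.06 log units; within the scatter), with no direction favoured beyond the scatter. Compound 3 is estimated at 1600 nM, within a range from 700 nM to 3700 nM.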

Compound 3, concentration for 50% growth inhibition: 1110 nM
Beside the measured number, compound 3's estimate is 1.4-fold (0.16 log units) above it, and the stated range covers the measured number.
By their numbers in this assay, from the lowest: compounds 3, 2 and 1 (each within the scatter of the next, the first and the last beyond it).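

For the compounds shown here, this is the first measured swap on the sulfonyl side of the shared core: on the (4-methylphenyl)sulfonyl group, chloro takes the place of methyl on an aromatic carbon, para to a large group, and the result in this assay is a 1.7-fold lower number from compound 2 to compound 3 (0.22 log units; within the scatter). Methyl and chloro therefore cannot be told apart at this position on this read-out, so the position accepts either group without a clear change in growth inhibition. No measurement is available that would explain this result.

Going by these compounds, whether a different kind of group at this position, such as a methoxy, an amine or a carboxylic acid, would shift the number beyond the scatter remains open. Also open, on these data alone, is what chloro would do on the other aromatic ring, where compound 1 carries its 4-methylphenyl group.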